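The compounds below may be only part of what the source reports. "The series", "measured", "known", "first", "only" and "open" are said of these compounds alone.

Going by the values given here, compound 1 `CCCCOC(=O)Nc1ccc(S(=O)(=O)N2C[C@H](c3ccccc3)NC2=O)cc1CC` is the one compound with a number in a functional assay on HCT-116 cells (Homo sapiens) for cytotoxicity, read by MTT assay (a higher number here means a weaker inhibitor, a lower number a stronger inhibitor), where compound 1 gives 200 nM. Compound 2 `Cc1cc(S(=O)(=O)N2C(=O)N[C@@H](c3ccccc3)C2C)ccc1NC(=O)c1ccc([N+](=O)[O-])cc1` in this assay returns only a limit, > 10000 nM. Among the compounds with values here, compound 1 therefore stands as the sole measured number, the other value being (the limit of > 10000 nM in this assay, at which 1 of the 2 values shown sits). Compound 3 `CCc1cc(S(=O)(=O)N2C[C@H](c3ccccc3)NC2=O)ccc1NC(=O)c1ccc(N)cc1` awaits measurement in this assay; it differs from compound 1 by 4-aminophenyl in place of butoxy on a carbonyl carbon. No step between measured compounds is shown, so the size is open; a moderate step toward weaker inhibition is expected, a 3.0-fold higher number from compound 1 to compound 3 (0.48 log units; beyond the scatter). Compound 3 is estimated at 600 nM, within 150 nM to 3000 nM.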

Compound 3, half-maximal inhibitory concentration: 460 nM
The estimate for compound 3 lay 1.3-fold (0.12 log units) above the measured number; the measured number falls inside the stated range.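

Going by these compounds alone, on a carbonyl carbon whose other neighbour is an amide-type nitrogen, 4-aminophenyl in place of butoxy gives the one readable step in this assay, which is a 2.3-fold higher number from compound 1 to compound 3 (0.36 log units; beyond the scatter). This position therefore takes an aromatic ring in place of an open chain, at a modest cost in inhibition. No measurement shown bears on the reason for this step.

The compounds shown leave open whether the step follows the ring or its amine, a question that plain phenyl on the same carbonyl carbon would separate. As far as these compounds go, how a shorter chain such as ethoxy would read here also remains open.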